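A few compounds are considered here, and "the series" means these few. Any claim that something is new, unique, unknown or untested is made for them only; others in the source may bear on it.

The measurements come from a functional assay on DLD-1 cells (Homo sapiens) for antiproliferative activity, read by CellTiter-Glo, with a stated time of 72 h; on this read-out lower numbers stand for stronger inhibition and higher numbers for weaker inhibition. Compound 1 `CC1CCN(C2CCN(S(=O)(=O)c3cccc(-c4ccccc4C(F)(F)F)c3)CC2)CC1` gives 10 nM there, and compound 3 `CC1CCN(C2CCN(S(=O)(=O)c3cnc(Cl)s3)CC2)CC1` gives 1800 nM. Compound 2 `Cc1cc(C)c(S(=O)(=O)N2CCC(C3OCC(C)CO3)CC2)c(C)c1` is different: for compound 2 the assay reports only a limit, > 5000 nM, not a number. As far as these compounds go, compound 2 thus stands at the limit of > 5000 nM in this assay, at which 1 of the 3 values shown sits, the edge beyond which nothing is measured, so its true potency is unknown apart from being weaker than that edge.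

Compound 4 `Cc1ccc(C2CCN(S(=O)(=O)c3c(C)cc(C)cc3C)CC2)cc1` is the next compound to be tested. It differs from compound 2 in a single place: a group of 7 heavy atoms (7 carbon; one six-membered aromatic ring of carbon only) in place of a group of 7 heavy atoms (5 carbon, 2 oxygen; one six-membered non-aromatic ring with 2 hetero atoms), on a saturated ring carbon. Within the data shown here, no measured pair of compounds differs in just this way, so the size of this step is an expectation rather than a measurement. The step is expected to be an at least 1.2-fold lower number from compound 2 to compound 4 (0.09 log units; that floor lies within the scatter), small and most likely not beyond the usual scatter, with compound 4 probably staying close to the limit. Compound 4 is therefore expected to give 4000 nM, with a range from 800 nM to 20000 nM.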

Compound 4, half-maximal inhibitory concentration: 2200 nM
For compound 4 the middle estimate is 1.8-fold (0.26 log units) above the measured one, and the stated range covers the measured number.
By their numbers in this assay, from the lowest: compound 1; then compounds 3 and 4 (each within the scatter of the next). At a limit, above all of these: compound 2.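

Here, for the first time, a change on the saturated ring carbon has a readable effect: in this assay, 4-methylphenyl in place of the six-membered ring with two oxygens gives an at least 2.2-fold lower number from compound 2 to compound 4 (0.35 log units; beyond the scatter). This shows that the group at this position, three ring bonds from the ring nitrogen, matters for the read-out, and that the all-carbon aromatic ring brings the compound onto the measurable scale. The step is only a minimum and its true size remains unknown, because compound 2 stands at a limit: the limit of > 5000 nM in this assay, at which 1 of the 4 values shown sits.

One pair cannot separate the effect of the aromatic ring from that of losing the two oxygens, and a cyclohexyl ring or an unsubstituted phenyl on the same carbon would help to tell them apart. As far as these compounds go, whether the step would carry over to other compounds, such as compound 1 or compound 3, also remains open.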